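The source may hold more compounds than are shown below. What is called first, only, known or untested is meant among the compounds shown, and "the series" means these compounds.

Measured compounds and their results in an ADME assay on the whole organism with Oryza sativa as the target, tested at 0.1 uM; a higher number here means a weaker effect of the compound at the concentration tested, a lower number a stronger effect:

- compound 1, `CCc1cccc(NC(=O)N[C@H](C)c2ccccc2)c1`: 97%
- compound 2, `CC(C)c1cccc(NC(=O)N[C@H](C)c2ccccc2)c1`: 74%
- compound 3, `CCCCc1ccc(NC(=O)N[C@H](C)c2ccccc2)cc1`: 100%

Compounds 1 and 2 share a core and differ by methyl in place of hydrogen on a saturated chain carbon bound to an aromatic carbon and a saturated chain carbon. Along this change the read-out moved by a number 23 percentage points lower from compound 1 to compound 2 (beyond the scatter). Compound 3 belongs to a different core; the difference between the two cores is not broken down here. In this assay compound 3 gives 100%, which lies close to what compound 1 gives and well apart from the value of compound 2.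

Compound 4, `CCCCCc1ccc(NC(=O)N[C@H](C)c2ccccc2)cc1`, has not yet been measured. It differs from compound 3 by methyl in place of hydrogen on a saturated chain carbon, four bonds along the chain from an aromatic carbon. For the measured compounds named here, this is the same kind of change as the one from compound 1 to compound 2, but not the same: there the methyl entered on a saturated chain carbon bound to an aromatic carbon and a saturated chain carbon, whereas here it enters on a saturated chain carbon, four bonds along the chain from an aromatic carbon.

Going by the values given here, the only measured step of this kind, a number 23 percentage points lower from compound 1 to compound 2 (beyond the scatter), was taken at a different place on the chain, so it is a loose guide at best. Since compound 3 already gives 100%, there is little room for the number to rise. Compound 4 is therefore expected to show a step of a number 5 percentage points lower from compound 3 to compound 4 (within the scatter) in this assay. The estimate for compound 4 is 95%, with a plausible range from 82% to 100%.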

Compound 4, a percentage reported as activity, at one concentration (the size of the read-out at that concentration, not a potency): 100%
Beside the measured number, compound 4's estimate is 5 percentage points below it, within the range that was stated.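

In this assay, the added methyl at the end of the chain of compound 3 leaves the read-out unmoved, with no change at the digits printed from compound 3 to compound 4 (within the scatter). Set beside the earlier step, the same kind of change does not carry over as a fixed shift from one core to the other: the same change on two cores in this assay, a number 23 percentage points lower (beyond the scatter) from compound 1 to compound 2 and no change at the digits printed (within the scatter) from compound 3 to compound 4, 23 percentage points apart, beyond the scatter of two such steps. The two pairs differ both in core and in the place where the methyl enters, so these results do not show which of the two accounts for the gap, and two steps give no rule for any further core.

The compounds shown leave open whether a methyl placed on the saturated chain carbon bound to an aromatic carbon, as in the step to compound 2, would lower the number on the core of compound 3 as well. They also leave open how a longer chain, or an ether, an amine or a carboxylic acid carried on the chain, would read in this assay.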